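The source may report more compounds than this note shows. Statements on the series, on what has been measured and on what is new or still open speak of the compounds shown alone.

Measured compounds:
compound 1 `CC1CC(=O)N(CC(=O)N2CCN(c3cccc(Cl)c3)CC2)C1=O` — 100 mg/kg
compound 2 `CCC1(C)CC(=O)N(CC(=O)N2CCN(c3cccc(C(F)(F)F)c3)CC2)C1=O` — 100 mg/kg

In a functional assay on the whole organism (strain CD1) with Mus musculus as the target, in the maximal electroshock model, with a stated time of 0.5 h (on this read-out lower numbers stand for an effect already at smaller amounts and higher numbers for an effect only at larger amounts of compound), compound 1 gives 100 mg/kg and compound 2 gives 100 mg/kg; the two values sit level within the scatter, so no order between them can be stated. Within the data shown here, no pair of measured compounds differing in a single place is at hand, so no measured step can guide the next move. Compound 3 `CC1CC(=O)N(CC(=O)N2CCN(c3ccccc3F)CC2)C1=O` differs from compound 1 by 2-fluorophenyl in place of 3-chlorophenyl on an amine nitrogen in a ring. Lacking any measured step of this kind, the expected step of no change at the digits printed from compound 1 to compound 3 (within the scatter) is none beyond the scatter. Compound 3 is therefore estimated at 100 mg/kg, with a range from 30 mg/kg to 300 mg/kg.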

Compound 3, minimum effective dose: 300 mg/kg
Estimate against measurement, compound 3: 3.0-fold (0.48 log units) below, and the stated range covers the measured number.
By their numbers in this assay, from the lowest: compounds 1 and 2 (each within the scatter of the next); then compound 3.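

In this assay, 2-fluorophenyl in place of 3-chlorophenyl on the amine nitrogen in a ring gives a 3.0-fold higher number from compound 1 to compound 3 (0.48 log units; beyond the scatter) as the first single-place change available here. The aryl group at this position therefore affects the dose needed, and this change moves the read-out toward larger amounts of compound. No evidence at hand accounts for the step. The halogen and its place on the phenyl change together, so the compounds shown do not separate the two. As far as these compounds go, how a plain phenyl or a methoxyphenyl would read at this nitrogen also remains open.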